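The compounds below may be only part of what the source reports. "The series", "measured", "known", "first", "only" and "open" are said of these compounds alone.

The core of compound 1 (`CCC1OCc2c(/C=C/C(C)=O)cnc(C)c2O1`) carries a saturated chain on a saturated ring carbon. Compound 2 (`CCCC1OCc2c(/C=C/C(C)=O)cnc(C)c2O1`) and compound 3 (`CCCCC1OCc2c(/C=C/C(C)=O)cnc(C)c2O1`) carry longer chains there. In a functional assay on MCF7 cells (Homo sapiens) for antiproliferative activity, read by MTT assay, with a stated time of 72 h (a lower number here means a stronger inhibitor, a higher number a weaker inhibitor), compound 1 gives 3900 nM, compound 2 gives 2200 nM and compound 3 gives 1300 nM. Compound 1 stands clearly apart only from compound 3, with a 3.0-fold lower number from compound 1 to compound 3 (0.48 log units; beyond the scatter). The smaller moves are a 1.8-fold lower number from compound 1 to compound 2 (0.25 log units; within the scatter) and a 1.7-fold lower number from compound 2 to compound 3 (0.23 log units; within the scatter).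

Compound 4 (`CCCCCCCCCC(C)C1OCc2c(/C=C/C(C)=O)cnc(C)c2O1`) has not yet been measured. Its change is nonyl in place of hydrogen on a saturated chain carbon bound to a saturated chain carbon and a saturated ring carbon. The measured steps bear on this only in part. They add carbon two or three bonds along the chain from the saturated ring carbon, and none adds a group at this place or anything as long as nonyl. Among the measured compounds shown here, the only step beyond the scatter, a 3.0-fold lower number from compound 1 to compound 3 (0.48 log units; beyond the scatter), suggests a modest fall of similar size in this assay, although a step in the other direction cannot be ruled out, so the range is wide. The expected change is a 3.3-fold lower number from compound 1 to compound 4 (0.51 log units; beyond the scatter). For compound 4 the estimated value is 1200 nM, with an expected range from 300 nM to 4500 nM.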

Compound 4, half-maximal inhibitory concentration: 2400 nM
Compound 4: the middle estimate sits 2.0-fold (0.30 log units) below what was measured, within the range that was stated.
By their numbers in this assay, from the lowest: compounds 3, 2, 4 and 1 (each within the scatter of the next, the first and the last beyond it).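

In this assay, among the compounds shown here, putting nonyl on a saturated chain carbon bound to a saturated chain carbon and a saturated ring carbon gives a 1.6-fold lower number from compound 1 to compound 4 (0.21 log units; within the scatter), so this place accepts a group of 9 carbon atoms with no clear shift in the number, which the earlier compounds could not show, as their steps add only methyl or ethyl elsewhere on the chain. For the compounds shown here, the one clear step among the earlier compounds, a 3.0-fold lower number from compound 1 to compound 3 (0.48 log units; beyond the scatter), finds no match here, so in this pair a large addition of plain carbon at this place brings no clear gain and no clear loss. Nothing available gives a reason for this result.

As far as these compounds go, what remains open is whether a small group at this same place, such as methyl alone, would behave like nonyl, and whether anything between methyl and nonyl would give a clear step. Also open, from the compounds shown here alone, is whether a chain ending in an amine or a carboxylic acid, rather than in plain carbon, would be accepted here as nonyl is in this assay, or would move the number clearly.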